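A few compounds are considered here, and "the series" means these few. Any claim that something is new, unique, unknown or untested is made for them only; others in the source may bear on it.

Measured compounds:
compound 1 `Cc1cc(C)c(NC(=O)N(Cc2ccc(N3CCN(C)CC3)cc2)C2CCCCCC2)c(C)c1`, 57 nM
compound 2 `Cc1cc(C)c(NC(=O)N(Cc2ccc(-c3ccnn3C)cc2)C2CCCCCC2)c(C)c1`, 24 nM
compound 3 `Cc1cc(C)c(NC(=O)N(Cc2ccc(-n3ccnc3)cc2)C2CCCCCC2)c(C)c1`, 47 nM

All three share one core and differ only in the ring attached to the aromatic carbon of the benzyl group. In an assay on microsomes from intestine for inhibition of acyl-CoA:cholesterol acyltransferase (Oryctolagus cuniculus) (on this read-out higher numbers stand for weaker inhibition and lower numbers for stronger inhibition), compound 3 gives 47 nM. Its number sits close to that of compound 1, shown by a 1.2-fold lower number from compound 1 to compound 3 (0.08 log units; within the scatter), and close to that of compound 2, shown by a 2.0-fold higher number from compound 2 to compound 3 (0.29 log units; within the scatter). The only step among these three that stands out is a 2.4-fold lower number from compound 1 to compound 2 (0.38 log units; beyond the scatter).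

Compound 4 `Cc1cc(C)c(NC(=O)N(Cc2ccc(-n3nccn3)cc2)C2CCCCCC2)c(C)c1` has not yet been measured. Compared with compound 3 the change is 2H-1,2,3-triazol-2-yl in place of 1H-imidazol-1-yl on an aromatic carbon. It is therefore another exchange of a small five-membered aromatic ring at the same place, exactly the kind of change the measured steps cover. Two of those steps, from compound 1 to compound 3 and from compound 2 to compound 3, stayed within the scatter; one, from compound 1 to compound 2, was modest. The expectation in this assay is a step of a 1.2-fold lower number from compound 3 to compound 4 (0.07 log units; within the scatter), which means no move beyond the scatter. Compound 4 is estimated at 40 nM, with a range from 18 nM to 90 nM.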

Compound 4, half-maximal inhibitory concentration: 130 nM
The estimate for compound 4 lay 3.3-fold (0.51 log units) below the measured number; measured number above the stated range.
By their numbers in this assay, from the lowest: compounds 2, 3 and 1 (each within the scatter of the next, the first and the last beyond it); then compound 4.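

In this assay, the first three rings at this position lay close together, yet a small exchange now gives a clear move, seen in a 2.8-fold higher number from compound 3 to compound 4 (0.44 log units; beyond the scatter). Both rings have 5 heavy atoms and no net charge, and the entering ring differs by holding 3 hetero atoms instead of 2, so a change this small in the ring on the aromatic carbon is enough to shift the number beyond the scatter. The other comparisons, a 5.4-fold higher number from compound 2 to compound 4 (0.73 log units; beyond the scatter) and a 2.3-fold higher number from compound 1 to compound 4 (0.36 log units; beyond the scatter), show that the new compound stands clear of all three earlier ones and is the weakest inhibitor of the four, and nothing measured here explains why.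

The compounds shown leave open whether the count of ring nitrogens matters or their arrangement, a question that a 1H-1,2,3-triazol-1-yl ring at the same place would help to separate from the 2H-1,2,3-triazol-2-yl result. They also leave open how a plain phenyl ring, with no nitrogen at all, or an open-chain amine would compare at this position.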